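Removing the Benzyloxycarbonyl Cap from Compound 2

The compounds below may be only part of what the source reports. "The series", "measured", "known", "first", "only" and "open" are said of these compounds alone.

Three compounds have been measured in a functional assay on MCF7 cells (Homo sapiens) for inhibition, read by MTT assay, with a stated time of 72 h; a higher number here means a weaker inhibitor, a lower number a stronger inhibitor:
Compound 1 `COc1ccc(Cn2cc(CSC(=S)N3CCN(C(=O)OCc4ccccc4)CC3)nn2)cc1` gives 30500 nM.
Compound 2 `Cc1ccc(Cn2cc(CSC(=S)N3CCN(C(=O)OCc4ccccc4)CC3)nn2)cc1` gives 37800 nM.
Compound 3 `O=C(OCc1ccccc1)N1CCN(C(=S)SCc2cn(Cc3ccc(Cl)c(Cl)c3)nn2)CC1` gives 10600 nM.

Compound 2 has the highest of the three numbers. Compound 1 sits next to it, with a 1.2-fold higher number from compound 1 to compound 2 (0.09 log units; within the scatter), so these two cannot be told apart. Compound 3 is the only one that stands clearly away: a 3.6-fold lower number from compound 2 to compound 3 (0.55 log units; beyond the scatter) and, from the other side, a 2.9-fold lower number from compound 1 to compound 3 (0.46 log units; beyond the scatter). Both of these modest steps come from the aryl group on the carbon bound to the aromatic nitrogen.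

Compound 4 `Cc1ccc(Cn2cc(CSC(=S)N3CCNCC3)nn2)cc1` is the new member. It differs from compound 2 by hydrogen in place of benzyloxycarbonyl on an amine nitrogen in a ring. Going by the values given here, none of the measured steps concerns this part of the molecule; every one of them changes the aryl group at the far end instead. Among the compounds with values here, there is thus no measured step that bears on this change, and the expectation for compound 4 rests only on the starting point, compound 2 at 37800 nM, with a wide range around it. Compound 4 is expected to give about 60000 nM, somewhere between 15000 nM and 200000 nM. The estimated step is a 1.6-fold higher number from compound 2 to compound 4 (0.20 log units; within the scatter), so compound 4 is expected to be a somewhat weaker inhibitor.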

Compound 4, half-maximal inhibitory concentration: 53200 nM
Beside the measured number, compound 4's estimate is 1.1-fold (0.05 log units) above it; measured number inside the range.
By their numbers in this assay, from the lowest: compound 3; then compounds 1, 2 and 4 (each within the scatter of the next).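

Replacing the benzyloxycarbonyl group, with its 10 heavy atoms and its own six-membered aromatic ring, by a hydrogen on the amine nitrogen gives a 1.4-fold higher number from compound 2 to compound 4 (0.15 log units; within the scatter), so the two compounds cannot be told apart in this assay. Going by these compounds alone, this is the first reading at this position, since every earlier step changed the aryl group on the saturated chain carbon bound to an aromatic nitrogen, and two of those steps, such as a 3.6-fold lower number from compound 2 to compound 3 (0.55 log units; beyond the scatter), went beyond the scatter, unlike this much larger structural change. Nothing shown here explains why the number stays within the scatter after so much of the molecule is removed.

On these data alone, this is a single pair, so it is open whether the same removal from compound 3, which carries the 3,4-dichlorophenyl group, would also stay within the scatter. As far as these compounds go, it is equally open whether a small group such as acetyl or methyl on this ring nitrogen, rather than hydrogen or the full benzyloxycarbonyl group, would give a number that stands apart from those of compound 2 and compound 4.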